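The compounds below may be only part of what the source reports. "The series", "measured", "known", "first", "only" and "open" are said of these compounds alone.

Three compounds that share one core were examined in a functional assay on MCF7 cells (Homo sapiens) for cytotoxicity, read by MTT assay, with a stated time of 24 h; a higher number here means a weaker inhibitor, a lower number a stronger inhibitor. Compound 1 `COC(=O)C[C@@H](NC(=O)Cn1cc(C2=C(c3c[nH]c4ccccc34)C(=O)N(C)C2=O)c2ccccc21)C(=O)OC` gives 25800 nM. Compound 2 `COC(=O)[C@H](NC(=O)Cn1cc(C2=C(c3c[nH]c4ccccc34)C(=O)N(C)C2=O)c2ccccc21)[C@@H](C)O` gives 22900 nM. Compound 3 `COC(=O)[C@H](NC(=O)Cn1cc(C2=C(c3c[nH]c4ccccc34)C(=O)N(C)C2=O)c2ccccc21)C(C)C` gives 16000 nM, the lowest of the three numbers, although its separations from the others, a 1.6-fold lower number from compound 1 to compound 3 (0.21 log units; within the scatter) and a 1.4-fold lower number from compound 2 to compound 3 (0.16 log units; within the scatter), both lie within the scatter. Compound 4 `COC(=O)CC[C@@H](NC(=O)Cn1cc(C2=C(c3c[nH]c4ccccc34)C(=O)N(C)C2=O)c2ccccc21)C(=O)OC` differs from compound 3 by 2-(methoxycarbonyl)ethyl in place of isopropyl on a saturated chain carbon bound to an amide-type nitrogen and a carbonyl carbon. Among the compounds with values here, the steps that bear on this change are the earlier exchanges at the same place, a 1.6-fold lower number from compound 1 to compound 3 (0.21 log units; within the scatter) and a 1.1-fold lower number from compound 1 to compound 2 (0.05 log units; within the scatter), neither of which moved the number beyond the scatter. The step is therefore expected to be small, a 1.4-fold higher number from compound 3 to compound 4 (0.14 log units; within the scatter). Compound 4 is expected to give about 22000 nM in this assay , with a range from 11000 nM to 45000 nM.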

Compound 4, half-maximal inhibitory concentration: 23400 nM
The estimate for compound 4 lay 1.1-fold (0.03 log units) below the measured number; the range from low to high includes it.
By their numbers in this assay, from the lowest: compounds 3, 2, 4 and 1 (each within the scatter of the next).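

In this assay, placing 2-(methoxycarbonyl)ethyl on the saturated chain carbon bound to an amide-type nitrogen and a carbonyl carbon changes nothing beyond the scatter, with a 1.5-fold higher number from compound 3 to compound 4 (0.17 log units; within the scatter) and a 1.0-fold higher number from compound 2 to compound 4 (0.01 log units; within the scatter). Lengthening the ester-bearing chain from (methoxycarbonyl)methyl to 2-(methoxycarbonyl)ethyl also leaves the number within the scatter, with a 1.1-fold lower number from compound 1 to compound 4 (0.04 log units; within the scatter), so this position has yet to show any response to the side chain. No supporting data bear on why these numbers stay so close. As far as these compounds go, whether a carboxylic acid, an amine or a benzyl group here would move the number beyond the scatter remains open.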